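This account rests on a few compounds, and the source may have more. Where it says the series, first, only, none or still open, it means among the compounds named here.

Working notes on the series. The two measured compounds share one core and differ only at the nitrogen bearing the aryl group. Compound 1 `Cc1cc(Nc2nc(Nc3ccccc3)nc3[nH]ncc23)n[nH]1` carries a phenyl there and in an assay on isolated protein for inhibition of serine/threonine-protein kinase PAK 4 (Homo sapiens), read by HTRF, with a stated time of 60 min (on this read-out lower numbers stand for stronger inhibition and higher numbers for weaker inhibition), compound 1 gives 5900 nM. Compound 2 `Cc1cc(Nc2nc(NCc3ccccc3)nc3[nH]ncc23)n[nH]1` carries a benzyl instead, and in this assay compound 2 gives 1960 nM. Among the compounds with values here, the single step in hand, a 3.0-fold lower number from compound 1 to compound 2 (0.48 log units; beyond the scatter), is a modest one. Within the data shown here, compound 2 therefore stands at the lowest of the two numbers, with compound 1 as its only neighbour.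

Compound 3 `Cc1cc(Nc2nc(NCc3ccccc3Cl)nc3[nH]ncc23)n[nH]1` is not yet measured. Relative to compound 2 the change is chloro in place of hydrogen on an aromatic carbon; read one bond further out, the benzyl becomes a 2-chlorobenzyl. Among the measured compounds shown here, no measured step touches this kind of change: the only step in hand, from compound 1 to compound 2, concerns the benzyl itself, not a substituent on it. The expectation in this assay is therefore a step of roughly a 1.3-fold lower number from compound 2 to compound 3 (0.12 log units; within the scatter), that is, nothing clearly beyond the scatter in either direction. Compound 3 is estimated at 1500 nM, within 500 nM to 4500 nM.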

Compound 3, half-maximal inhibitory concentration: 668 nM
Beside the measured number, compound 3's estimate is 2.2-fold (0.35 log units) above it, within the range that was stated.
By their numbers in this assay, from the lowest: compound 3; then compound 2; then compound 1.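

In this assay the aromatic ring of the benzyl proves responsive to substitution: chloro in place of hydrogen, ortho to a large group, gives a 2.9-fold lower number from compound 2 to compound 3 (0.47 log units; beyond the scatter) and so shows that the number moves at this ring, not only at the change from phenyl to benzyl. The two changes together, 2-chlorobenzyl in place of phenyl, give an 8.8-fold lower number from compound 1 to compound 3 (0.95 log units; beyond the scatter) and leave compound 3 with the lowest number of the three. No evidence is at hand to explain the effect of chloro at this place.

The compounds shown leave open whether the step is specific to chloro or would also appear with a methyl, a methoxy or an amine at this place. They also leave open how chloro would read elsewhere on the ring, since only this one place is shown.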